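The compounds below may be only part of what the source reports. "The series", "measured", "known", "first", "only" and "open" are said of these compounds alone.

Of the compounds shown here, two that share one core have so far been measured in a functional assay on the whole organism (strain Kunming) with Mus musculus as the target, with a stated time of 30 min; on this read-out lower numbers stand for an effect already at smaller amounts and higher numbers for an effect only at larger amounts of compound. Compound 1 `CCCCCCSc1nnc(COc2ccc3c(c2)CCC(=O)N3)o1` gives 10.4 mg/kg in this assay, the lower of the two numbers recorded. Compound 2 `CCCCCCSc1nnc(COc2ccc(NC(C)=O)cc2)o1` gives 20.9 mg/kg in this assay; the two values lie within the scatter of each other, so the data show no real gap between them. Compound 3 `CCCCCSc1nnc(COc2ccc3c(c2)CCC(=O)N3)o1` has not yet been measured in this assay. It differs from compound 1 in a single place: hydrogen in place of methyl on a saturated chain carbon, five bonds along the chain from a sulfur. Among the compounds with values here, no pair of measured compounds shows what such a change does in this assay, so nothing is known here about how the read-out answers to it. Since only a methyl leaves the end of a saturated chain and everything else is kept, the step of a 1.2-fold higher number from compound 1 to compound 3 (0.06 log units; within the scatter) is expected to stay within the scatter, in no clear direction. Compound 3 is therefore expected to give about 12 mg/kg in this assay, with a range from 6 mg/kg to 25 mg/kg.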

Compound 3, dose for half-maximal effect: 8.9 mg/kg
Compound 3: middle estimate off by 1.3-fold (0.13 log units), on the high side; low and high end bracket the measured number.
By their numbers in this assay, from the lowest: compounds 3, 1 and 2 (each within the scatter of the next, the first and the last beyond it).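

In this assay, within the data shown here, replacing the methyl with hydrogen on a saturated chain carbon, five bonds along the chain from a sulfur, gives a 1.2-fold lower number from compound 1 to compound 3 (0.07 log units; within the scatter), and this pair offers the first direct look at what this change does. At this place, then, the loss of one carbon leaves the read-out without a difference that can be told apart from ordinary repeat variation, so this methyl is not needed to keep the effect at the level seen for compound 1; a single pair cannot say that the same would hold on another core or for a larger change to the chain. No supporting measurement bears on why the read-out stays put here.

On these data alone, what remains open is how far this tolerance reaches: one step says nothing about whether the chain could be cut back further, or whether a longer chain would leave the read-out just as unmoved. As far as these compounds go, it is also open whether the read-out would stay in this range with a different kind of group on that saturated chain carbon, such as an amine or a carboxylic acid, in place of the methyl.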